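The source may hold more compounds than are shown below. What is called first, only, known or untested is meant among the compounds shown, and "the series" means these compounds.

Compound 1, `Cc1ccc(CCC(=O)N[C@@H](C(=O)N2CCC(c3ccc(Cl)cc3)CC2)C(C)C)cc1`: 105 nM
Compound 2, `CC(C)CCC(=O)N[C@@H](C(=O)N1CCC(c2ccc(Cl)cc2)CC1)C(C)C`: 26 nM
Compound 3, `CC(C)[C@@H](NC(=O)CC1CC1)C(=O)N1CCC(c2ccc(Cl)cc2)CC1`: 46 nM

In an assay on THP-1 cells for displacement of a labelled ligand from C-C chemokine receptor type 1 (Homo sapiens) (a lower number here means a stronger inhibitor, a higher number a weaker inhibitor), compound 3 stands second highest of the three numbers: close to compound 2, since a 1.8-fold higher number from compound 2 to compound 3 (0.25 log units; within the scatter), while the gap to compound 1 is real, a 2.3-fold lower number from compound 1 to compound 3 (0.36 log units; beyond the scatter). Compound 4, `CC(C)[C@@H](NC(=O)NCc1ccccc1)C(=O)N1CCC(c2ccc(Cl)cc2)CC1`, differs from compound 3 in one place: benzylamino in place of cyclopropylmethyl on a carbonyl carbon. The two measured steps that also change the group on the acyl side, a 2.3-fold lower number from compound 1 to compound 3 (0.36 log units; beyond the scatter) and a 1.8-fold higher number from compound 2 to compound 3 (0.25 log units; within the scatter), were modest, with the aryl-bearing compound 1 giving the highest number. Within the data shown here, no measured step puts a nitrogen on the carbonyl, so the urea itself is untested. A modest rise is expected, a 2.0-fold higher number from compound 3 to compound 4 (0.29 log units; within the scatter). Compound 4 is therefore estimated at 90 nM, within 30 nM to 300 nM.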

Compound 4, half-maximal inhibitory concentration: 180 nM
Beside the measured number, compound 4's estimate is 2.0-fold (0.30 log units) below it; low and high end bracket the measured number.
By their numbers in this assay, from the lowest: compounds 2 and 3 (each within the scatter of the next); then compounds 1 and 4 (each within the scatter of the next).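

Benzylamino on the carbonyl carbon gives a clear loss against the two small alkyl groups, with a 3.9-fold higher number from compound 3 to compound 4 (0.59 log units; beyond the scatter) and a 6.9-fold higher number from compound 2 to compound 4 (0.84 log units; beyond the scatter). Against the other compound with an aromatic ring, there is no real gap, with a 1.7-fold higher number from compound 1 to compound 4 (0.23 log units; within the scatter), so among these four compounds, compounds 1 and 4 form the weaker pair, with no compound going against this. Nothing here offers an explanation for this pattern.

On these data alone, compound 4 adds the nitrogen and the aromatic ring together, so their separate contributions remain open. Isopentylamino on the same carbonyl carbon would test the nitrogen without the ring.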